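Swapping the aryl carbinol for a methylamide

The source may hold more compounds than are shown below. What is called first, only, known or untested is meant among the compounds shown, and "the series" means these compounds.

Compound 3 `CC#C[C@H]1CN(S(=O)(=O)c2ccc(N)nc2)CCN1c1ccc(C(O)(CC#N)C(F)(F)F)cc1` gives 219 nM in an assay on cells (Hepatocyte) for inhibition of glucokinase regulatory protein (Mus musculus), with stated times of 20 min and 40 min (on this read-out lower numbers stand for an effect already at smaller amounts and higher numbers for an effect only at larger amounts of compound), the higher of the two numbers shown. Compound 1 `CC#CCC(O)(c1ccc(N2CCN(S(=O)(=O)c3ccc(N)nc3)C[C@@H]2C#CC)cc1)C(F)(F)F` gives 137 nM, and the step is a 1.6-fold higher number from compound 1 to compound 3 (0.20 log units; within the scatter). Compound 2 `CC#C[C@H]1CN(S(=O)(=O)c2ccc(N)nc2)CCN1c1ccc(C(C)=O)cc1` gives only a limit of the assay, > 12500 nM. That limit is the limit of > 12500 nM in this assay, at which 1 of the 3 values shown sits.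

Compound 4 `CC#C[C@H]1CN(S(=O)(=O)c2ccc(N)nc2)CCN1c1ccc(C(=O)NC)cc1` differs from compound 3 by a group of 4 heavy atoms (2 carbon, 1 nitrogen, 1 oxygen; no ring) in place of a group of 9 heavy atoms (4 carbon, 1 nitrogen, 1 oxygen, 3 fluorine; no ring), on an aromatic carbon. Within the data shown here, two measured steps bear on this change: the carbinol on the aryl ring was exchanged for a small carbonyl-bearing group in an at least 91-fold higher number from compound 1 to compound 2 (1.96 log units; beyond the scatter), and the reverse exchange gave an at least 57-fold lower number from compound 2 to compound 3 (1.75 log units; beyond the scatter). Compound 4 carries a small carbonyl-bearing group in the same position, so a large rise in number is expected in this assay, a step estimated as a 37-fold higher number from compound 3 to compound 4 (1.56 log units; beyond the scatter), with a real chance that only a limit is reported. Compound 4 is therefore estimated at 8000 nM, with an expected range from 1500 nM to 40000 nM.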

Compound 4, half-maximal effective concentration: 4050 nM
The estimate for compound 4 lay 2.0-fold (0.30 log units) above the measured number; the measured number falls inside the stated range.
By their numbers in this assay, from the lowest: compounds 1 and 3 (each within the scatter of the next); then compound 4. At a limit, above all of these: compound 2.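

Exchanging either carbinol for methylcarbamoyl on this aromatic carbon raises the number substantially in this assay, with an 18-fold higher number from compound 3 to compound 4 (1.27 log units; beyond the scatter) and a 30-fold higher number from compound 1 to compound 4 (1.47 log units; beyond the scatter). The amide nevertheless gives a measured number where the methyl ketone does not, with methylamino in place of methyl on the carbonyl carbon giving an at least 3.0-fold lower number from compound 2 to compound 4 (0.48 log units; beyond the scatter), so a carbonyl-bearing group here does not by itself push a compound out of the measurable range. That step has only one firm end, as the value of compound 2 is a limit: the limit of > 12500 nM in this assay, at which 1 of the 4 values shown sits.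

Which part of the carbinol group accounts for the gap to the amide stays open, as the hydroxyl and trifluoromethyl change together in these steps. Going by these compounds, it is also open how a primary amide, a dimethylamide or a carboxylic acid on the same carbon would compare.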